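Swapping the oxadiazole isomer on a biaryl bradykinin antagonist

A few compounds are considered here, and "the series" means these few. Any claim that something is new, unique, unknown or untested is made for them only; others in the source may bear on it.

Measured compounds:
- compound 1, `Cc1nc(-c2c(F)cccc2-c2ccc([C@@H](C)Nc3nccc(Cl)c3NC(=O)CC#N)cc2)no1`: 0.7 nM
- compound 2, `COC(=O)c1ccc(Cl)cc1-c1ccc([C@@H](C)Nc2nccc(Cl)c2NC(=O)CC#N)cc1`: 0.8 nM

In an assay on CHO cells for displacement of a labelled ligand from B1 bradykinin receptor (Homo sapiens) (a lower number here means a stronger inhibitor, a higher number a weaker inhibitor), compound 1 gives 0.7 nM, the lowest of the two numbers shown. Compound 2 gives 0.8 nM in this assay, a number that sits within the scatter of that of compound 1, so the two are not separated by these data. The unmeasured compound 3, `Cc1noc(-c2c(F)cccc2-c2ccc([C@@H](C)Nc3nccc(Cl)c3NC(=O)CC#N)cc2)n1`, is built from compound 1 by an exchange of one group for another of the same atoms, joined differently: 3-methyl-1,2,4-oxadiazol-5-yl in place of 5-methyl-1,2,4-oxadiazol-3-yl on an aromatic carbon. Among the compounds with values here, no step between measured compounds isolates a change of this kind. A neutral position is therefore taken: no step beyond the scatter is expected in either direction, and the number is estimated to come out as a 1.4-fold higher number from compound 1 to compound 3 (0.15 log units; within the scatter) in this assay. Compound 3 is thus expected to give about 1 nM, within a range of 0.4 nM to 3 nM.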

Compound 3, inhibition constant: 0.5 nM
Compound 3: the middle estimate sits 2.0-fold (0.30 log units) above what was measured, and the stated range covers the measured number.
By their numbers in this assay, from the lowest: compounds 3, 1 and 2 (each within the scatter of the next).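

In this assay, putting 3-methyl-1,2,4-oxadiazol-5-yl in place of 5-methyl-1,2,4-oxadiazol-3-yl on this aromatic carbon, ortho to a fluoro group, gives a 1.4-fold lower number from compound 1 to compound 3 (0.15 log units; within the scatter). Within the data shown here, this direct comparison, which the earlier compounds could not provide, does not separate the two isomers, so at this position how the atoms of the methyl-oxadiazole are joined has no effect that these data can resolve. Nothing available bears on why the two isomers are not separated.

The compounds shown leave open whether this position would give a comparable number with a different group on the aromatic carbon, such as a carboxylic acid or an amine. They also leave open what a longer chain, such as ethyl or propyl, would do in place of the methyl on the oxadiazole.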